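The source may report more compounds than this note shows. Statements on the series, on what has been measured and on what is new or still open speak of the compounds shown alone.

Measured so far in a functional assay on HeLa cells (Homo sapiens) for inhibition; a higher number here means a weaker inhibitor, a lower number a stronger inhibitor:
- compound 1 `O=C(CC(CC(=O)NC1Cc2ccccc2C1)c1ccc(Cl)cc1)NCCN1CCCC1`: 77300 nM
- compound 2 `CCN(C(=O)CC(CC(=O)NCCN1CCCCC1)c1ccc(Cl)cc1)C1Cc2ccccc2C1`: 20400 nM

Compound 2 holds the lower of the two numbers at 20400 nM, and its gap to compound 1 lies beyond the scatter. Compound 3 `CCN(C(=O)CC(CC(=O)NCCN1CCCC1)c1ccc(Cl)cc1)C1Cc2ccccc2C1` is the next to be read. It departs from compound 2 in one place: pyrrolidin-1-yl in place of piperidin-1-yl on a saturated chain carbon, two bonds along the chain from an amide-type nitrogen. That is, pyrrolidin-1-yl stands in place of piperidin-1-yl on a saturated chain carbon, two bonds along the chain from an amide-type nitrogen. For the measured compounds named here, compound 1 also carries pyrrolidin-1-yl, but it differs from compound 2 in more than one place, so no measured pair isolates this change. Only a small rise of the number in this assay, none beyond the scatter, is expected. The estimated move is a 1.2-fold higher number from compound 2 to compound 3 (0.09 log units; within the scatter). For compound 3 the expected value is 25000 nM, with an estimated range of 11000 nM to 56000 nM.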

Compound 3, half-maximal inhibitory concentration: 36400 nM
Compound 3: middle estimate off by 1.5-fold (0.16 log units), on the low side, and the stated range covers the measured number.
By their numbers in this assay, from the lowest: compounds 2 and 3 (each within the scatter of the next); then compound 1.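

In this assay the swap to pyrrolidin-1-yl from piperidin-1-yl on a saturated chain carbon, two bonds along the chain from an amide-type nitrogen, gives a 1.8-fold higher number from compound 2 to compound 3 (0.25 log units; within the scatter) and so is not separated from repeat-measurement scatter at this position. For the compounds shown here, compound 3 also isolates a second change for the first time: ethyl in place of hydrogen on an amide-type nitrogen gives a 2.1-fold lower number from compound 1 to compound 3 (0.33 log units; beyond the scatter) as a modest single-place step. Nothing available explains the size of either step.

On these data alone, it remains open whether morpholin-4-yl or an open-chain dimethylamino group at the chain end would also stay within the scatter of compound 2. Also open, as far as these compounds go, are whether a propyl group can replace the ethyl group and whether the ethyl step carries over to the piperidin-1-yl compounds.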